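Azide to Amine on a Dialkylated Aminoglycoside Scaffold

The source may hold more compounds than are shown below. What is called first, only, known or untested is meant among the compounds shown, and "the series" means these compounds.

Measured so far:
compound 1, `CCCCCCCCCO[C@@H]1[C@@H](N)[C@@H](OC[C@H](O)CN=[N+]=[N-])O[C@H](CN)[C@H]1OCCCCCCCCC` — 62.2%
compound 2, `CCCCCCCCCO[C@@H]1[C@@H](N)[C@@H](O[C@H]2[C@H](O)[C@@H](OCCCCCCCCC)[C@H](N)C[C@@H]2N)O[C@H](CN)[C@H]1O` — 78.4%

In a toxicity assay on the whole organism (J774 cells) for cytotoxicity, with Mus musculus as the target, read by MTT assay, with a stated time of 24 h, tested at 10 uM (a higher number here means a weaker effect of the compound at the concentration tested, a lower number a stronger effect), compound 1 gives 62.2%, the lowest of the two numbers; compound 2 gives 78.4%, a gap beyond the usual scatter. Compound 3, `CCCCCCCCCO[C@@H]1[C@@H](N)[C@@H](OC[C@@H](O)CN)O[C@H](CN)[C@H]1OCCCCCCCCC`, is not yet measured. It differs from compound 1 in one place: 2-amino-1-hydroxyethyl in place of 2-azido-1-hydroxyethyl on a saturated chain carbon bound to an oxygen on a saturated carbon. Within the data shown here, no measured pair shows this change, so its effect is unknown. A small step from compound 1 to compound 3 is expected, within the scatter, perhaps slightly upward: a number 5.8 percentage points higher from compound 1 to compound 3 (within the scatter). For compound 3 the estimate is 68%, between 50% and 86%.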

Compound 3, a percentage reported as activity, at one concentration (the size of the read-out at that concentration, not a potency): 85.1%
The estimate for compound 3 lay 17.1 percentage points below the measured number; the measured number falls inside the stated range.
By their numbers in this assay, from the lowest: compound 1; then compounds 2 and 3 (each within the scatter of the next).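

In this assay, putting 2-amino-1-hydroxyethyl in place of 2-azido-1-hydroxyethyl gives a number 22.9 percentage points higher from compound 1 to compound 3 (beyond the scatter). This single pair shows that the change at this place on the saturated chain carbon can shift the read-out: the compound with the azide has the stronger effect at the concentration tested, and the one with the amine the weaker. Nothing available here explains this shift. The compounds shown leave open how a guanidine or a carboxylic acid at this place would read, and whether the step would hold on a core with other chains.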